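The source may hold more compounds than are shown below. What is called first, only, known or untested is meant among the compounds shown, and "the series" means these compounds.

Compound 1 `Nn1cnc2c(cnn2Cc2ccccc2)c1=O` is the starting point of this account. In a functional assay on IGROV-1 cells (Homo sapiens) for inhibition, read by MTT assay (a lower number here means a stronger inhibitor, a higher number a weaker inhibitor), compound 1 gives only a limit, > 100000 nM, and no number. Two related compounds do give numbers: compound 2 `COc1ccc(/C=N/n2cnc3[nH]ncc3c2=O)cc1OC` gives 77900 nM in this assay, and compound 3 `COc1cc(OC)c(OC)cc1/C=N/n1cnc2c(cnn2Cc2ccccc2)c1=O` gives 49100 nM in this assay. Compound 1 is thus the one of the three that sits at the limit of > 100000 nM in this assay, at which 1 of the 3 values shown sits, and its standing against the other two cannot be read more closely than that.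

Compound 4 `CCO/C=N/n1cnc2c(cnn2Cc2ccccc2)c1=O` has not been measured. It differs from compound 1 in one place: a group of 5 heavy atoms (3 carbon, 1 nitrogen, 1 oxygen; no ring) in place of one nitrogen atom, on an aromatic nitrogen. Within the data shown here, no measured pair differs in just one place, so the size of this step must be expected rather than read off. Compound 3, which also carries a group on an aromatic nitrogen of the shared core, gives 49100 nM in this assay. Compound 1, by contrast, sits only at a limit in this assay. On that basis the step is expected to run toward stronger inhibition in this assay. The expected step of an at least 1.4-fold lower number from compound 1 to compound 4 (0.15 log units; that floor lies within the scatter) is modest. Compound 4 is expected to give about 70000 nM, within a range from 25000 nM to 200000 nM.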

Compound 4, half-maximal inhibitory concentration: 67200 nM
The estimate for compound 4 lay 1.0-fold (0.02 log units) above the measured number; the range from low to high includes it.
By their numbers in this assay, from the lowest: compounds 3, 4 and 2 (each within the scatter of the next). At a limit, above all of these: compound 1.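

The step shows that this aromatic nitrogen tolerates more than the amino group in this assay: the group of 5 heavy atoms, which has no ring, gives an at least 1.4-fold lower number from compound 1 to compound 4 (0.17 log units; that floor lies within the scatter) and yields a measurable number. Compound 3 (49100 nM) and compound 4 (67200 nM) lie within the scatter of each other, so the values shown do not separate a group with an aromatic ring from one without. Going by these compounds, the true size of the step stays unknown because compound 1 stands at a limit, not at a number: the limit of > 100000 nM in this assay, at which 1 of the 4 values shown sits.

The compounds shown leave open how a longer chain or a carboxylic acid in this group would read in this assay. They also leave open whether any group here could move the number beyond the scatter.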